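Swapping fluoropyridine for methyltriazole: an expected solubility gain

The compounds below may be only part of what the source reports. "The series", "measured", "known", "first", "only" and "open" are said of these compounds alone.

Compound 2 `Cc1cc(NCc2ccc(F)cn2)n2nc(C)c(-c3ccccc3)c2n1` has been measured in a physicochemical assay for solubility, read by HPLC, using the shake flask method, measured as kinetic solubility, with a stated time of 2 h, at pH 7.4; a higher number here means a more soluble compound, a lower number a less soluble compound. In that test compound 2 gives < 5000 nM, which is a limit of the assay rather than a number, as stated in the limit of < 5000 nM in this assay, at which 1 of the 2 values shown sits. Compound 1 `Cc1cc(NCc2c[nH]cn2)n2nc(C)c(-c3ccccc3)c2n1`, carrying 1H-imidazol-4-yl at the same place, gives 14600 nM in this assay. Among the measured compounds shown here, the single measured step, an at least 2.9-fold lower number from compound 1 to compound 2 (0.46 log units; beyond the scatter), is the only guide available. Compound 3 `Cc1cc(NCc2ncnn2C)n2nc(C)c(-c3ccccc3)c2n1` is not yet measured; it differs from compound 2 by 1-methyl-1H-1,2,4-triazol-5-yl in place of 5-fluoropyridin-2-yl on a saturated chain carbon bound to a nitrogen on an aromatic ring. Since the step of an at least 2.9-fold lower number from compound 1 to compound 2 (0.46 log units; beyond the scatter) lowered the number when 1H-imidazol-4-yl gave way to 5-fluoropyridin-2-yl, removing 5-fluoropyridin-2-yl again in favour of 1-methyl-1H-1,2,4-triazol-5-yl is expected to raise it, roughly by an at least 2.0-fold higher number from compound 2 to compound 3 (0.30 log units; that floor lies within the scatter), though a start from a limit leaves the size uncertain. For compound 3 the estimated value in this assay is 10000 nM, within 3000 nM to 30000 nM.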

Compound 3, solubility: 185000 nM
Compound 3: middle estimate off by 19-fold (1.27 log units), on the low side; the whole stated range lies below it.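

In this assay, the group on a saturated chain carbon bound to a nitrogen on an aromatic ring proves able to shift the number by a wide margin: putting 1-methyl-1H-1,2,4-triazol-5-yl in place of 5-fluoropyridin-2-yl gives an at least 37-fold higher number from compound 2 to compound 3 (1.56 log units; beyond the scatter). The triazole does more than restore the level set by 1H-imidazol-4-yl, since replacing that group gives a 13-fold higher number from compound 1 to compound 3 (1.10 log units; beyond the scatter). The first of these steps starts from a limit of the assay held by compound 2, not from a number: the limit of < 5000 nM in this assay, at which 1 of the 3 values shown sits.

From the compounds shown here alone, what stays open is which feature of the triazole carries the rise, as the ring and its methyl enter together here. The same ring without its methyl, or a plain pyridin-2-yl, would help to separate these features, and the step has been seen on this one core only.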